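Fixing one ring stereocentre in compound 3

This account rests on a few compounds, and the source may have more. Where it says the series, first, only, none or still open, it means among the compounds named here.

compound 1 `CS(=O)(=O)N1CCCC(NC(=O)[C@H](CCC2CCCCC2)NC(=O)c2ccc(CNC(=O)c3cc(-c4ccccc4)n[nH]3)cc2)C1`: 21500 nM
compound 2 `CC(NC(=O)c1cc(-c2ccccc2)n[nH]1)c1ccc(C(=O)N[C@@H](CCC2CCCCC2)C(=O)NC2CCCN(S(C)(=O)=O)C2)cc1`: 27700 nM

In an assay on HEK293T cells for inhibition of Discoidin domain-containing receptor 2 (Homo sapiens), read by NanoBRET, with a stated time of 2 h (on this read-out lower numbers stand for stronger inhibition and higher numbers for weaker inhibition), compound 1 gives 21500 nM and compound 2 gives 27700 nM; the step of a 1.3-fold higher number from compound 1 to compound 2 (0.11 log units; within the scatter) lies within the scatter, so compound 2 and compound 1 stand level on these two numbers. Compound 3 `CC(NC(=O)c1cc(-c2ccccc2)n[nH]1)c1ccc(C(=O)N[C@@H](CCC2CCCCC2)C(=O)N[C@H]2CCCN(S(C)(=O)=O)C2)cc1` keeps every atom and bond of compound 2: the two compounds have the same atoms and bonds; at least one stereo element is drawn with a configuration in one of them and without one in the other: 1 of 3 stereo elements differ; a stereocentre at a saturated ring carbon is drawn without a configuration in compound 2 and S in compound 3. Within the data shown here, the one measured step concerns a different site, so no measured step bears on drawing this configuration. The expected step of a 1.3-fold lower number from compound 2 to compound 3 (0.10 log units; within the scatter) is therefore none beyond the scatter, in either direction. Compound 3 is estimated at 22000 nM, range 8000 nM to 60000 nM.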

Compound 3, half-maximal inhibitory concentration: 22000 nM
Compound 3: the middle estimate sits on the measured number at the digits printed, within the range that was stated.
By their numbers in this assay, from the lowest: compounds 1, 3 and 2 (each within the scatter of the next).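

In this assay, defining the saturated ring carbon as S gives a 1.3-fold lower number from compound 2 to compound 3 (0.10 log units; within the scatter), so the S form and the form drawn without a configuration stand level at this position. Among these compounds, the earlier step concerned a saturated chain carbon, so this is the first reading at the ring stereocentre. The comparison rests on a difference in drawing alone: the fact that one of compounds 2 and 3 is drawn with a defined configuration and the other without, at the place where they differ

The compounds shown leave open how the R configuration at this ring carbon reads. Also open, from the compounds shown here alone, is whether an acetyl group or a free amine in place of the methanesulfonyl group would read differently.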